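The source may hold more compounds than are shown below. What is called first, only, known or untested is meant among the compounds shown, and "the series" means these compounds.

Measured so far in an assay on isolated protein for inhibition of protein deacetylase HDAC6 (Homo sapiens), read by fluorescence, with stated times of 10 min and 2 h; on this read-out lower numbers stand for stronger inhibition and higher numbers for weaker inhibition:
Compound 1 `CCCN1CC(=O)N(Cc2ccc(C(=O)NO)cc2)C1=O`: 53.4 nM
Compound 2 `CC(C)(C)c1ccc(CN2CC(=O)N(Cc3ccc(C(=O)NO)cc3)C2=O)cc1`: 40.7 nM
Compound 3 `CC1(c2ccccc2)NC(=O)N(Cc2ccc(C(=O)NO)cc2)C1=O`: 74.9 nM

Compound 3 shows the highest of the three numbers, yet its gaps to compound 1 and to compound 2 both lie within the usual scatter, so on this read-out the three compounds cannot be told apart. Compound 4 `COc1ccc(CC2(c3ccccc3)NC(=O)N(Cc3ccc(C(=O)NO)cc3)C2=O)cc1` differs from compound 3 by a single change: 4-methoxyphenyl in place of hydrogen on a saturated chain carbon bound to a saturated ring carbon. For the measured compounds named here, no pair of measured compounds maps this step directly. What compound 1 and compound 2 do show is that two quite different substituents on the shared core give values within the scatter of each other, so no step beyond the scatter is expected here. For compound 4 the estimate is 50 nM, with a range from 20 nM to 130 nM, an expected step of a 1.5-fold lower number from compound 3 to compound 4 (0.18 log units; within the scatter).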

Compound 4, half-maximal inhibitory concentration: 72.4 nM
For compound 4 the middle estimate is 1.4-fold (0.16 log units) below the measured one, and the stated range covers the measured number.
By their numbers in this assay, from the lowest: compounds 2, 1, 4 and 3 (each within the scatter of the next).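

In this assay, for the compounds shown here, 4-methoxyphenyl in place of hydrogen on a saturated chain carbon bound to a saturated ring carbon gives a 1.0-fold lower number from compound 3 to compound 4 (0.01 log units; within the scatter), the only step here between compounds that differ in one place. At this position, a group of 8 heavy atoms enters and the two numbers lie within the scatter of each other. Nothing available here offers an explanation for this result. The compounds shown leave open how an amine, a carboxylic acid or a longer chain at this position would read.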